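Para-linked aryl swap: pyridine to pyrazole on compound 3

A few compounds are considered here, and "the series" means these few. Any claim that something is new, unique, unknown or untested is made for them only; others in the source may bear on it.

Compound 3 `CNC(=O)N1CCCc2ccc(NC(=O)c3ccc(-c4cccnc4)cc3)cc21` stands at the top of the three values in a functional assay on MV4-11 cells (Homo sapiens) for antiproliferative activity, with a stated time of 6 days, tested at 1.56 uM (on this read-out lower numbers stand for a weaker effect and higher numbers for a stronger effect at the one concentration tested), where compound 3 gives 62.5%. Compound 2 `CNC(=O)N1CCCc2ccc(NC(=O)c3cccc(-c4ccn(C(C)=O)n4)c3)cc21` gives 27.6%, and compound 1 `CNC(=O)N1CCCc2ccc(NC(=O)c3cccc(-c4ccccc4)c3)cc21` gives 2.83%. For the measured compounds named here, the one single-point step on record is heteroaryl in place of phenyl: a number 24.8 percentage points higher from compound 1 to compound 2 (beyond the scatter). The step to compound 4 `CNC(=O)N1CCCc2ccc(NC(=O)c3ccc(-c4cn[nH]c4)cc3)cc21` is 1H-pyrazol-4-yl in place of pyridin-3-yl on an aromatic carbon. Going by the values given here, it has no direct counterpart: the step from compound 1 to compound 2 concerns a different five-membered ring entering for phenyl on a different carbon of the ring, and not a pyridine leaving. It shows only that a small nitrogen heterocycle at that position is tolerated and can raise the read-out. For this assay a step of modest size in either direction, or none beyond the scatter, is therefore expected for compound 4, with a slight lean downward as the entering ring is smaller and differs in donor count; the expected step is a number 12.5 percentage points lower from compound 3 to compound 4 (beyond the scatter). Compound 4 is estimated at 50%, within 25% to 75%.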

Compound 4, a percentage reported as inhibition, at one concentration (the size of the read-out at that concentration, not a potency): 73.5%
Compound 4: middle estimate off by 23.5 percentage points, on the low side, within the range that was stated.
By their numbers in this assay, from the lowest: compound 1; then compound 2; then compound 3; then compound 4.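

In this assay, a number 11 percentage points higher from compound 3 to compound 4 (beyond the scatter), so at this aromatic carbon, para to a large group, 1H-pyrazol-4-yl replaces pyridin-3-yl with a rise in the read-out. This is the only pair shown in which one nitrogen heterocycle replaces another at this place, and it indicates that a six-membered aromatic ring is not required here, since the five-membered ring with one hydrogen-bond donor serves at least as well. No measurement on hand bears on why the read-out rises with this swap.

Still open, from the compounds shown here alone, is whether the rise depends on the ring's donor or on the ring itself, a question that a 1-methyl-1H-pyrazol-4-yl group at the same carbon would address. Going by these compounds, how a carboxylic acid or an aminomethyl group on this ring would fare also remains open.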